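Removing a methoxy group from the lead nitro compound

The source may hold more compounds than are shown below. What is called first, only, known or untested is meant among the compounds shown, and "the series" means these compounds.

In a functional assay on T47D cells (Homo sapiens) for antiproliferative activity, read by MTT assay, with a stated time of 72 h (a higher number here means a weaker inhibitor, a lower number a stronger inhibitor), compound 1 `CCCCCn1ccnc1-c1cc(OC)c(OC)c(OC)c1` gives 64400 nM. For compound 2 `COc1cc(-c2nccn2Cc2ccccc2)cc(OC)c1OC` the entry > 100000 nM is a limit of the assay. Compound 3 `COc1ccc(-n2ccnc2-c2cc(OC)c(OC)c(OC)c2)cc1[N+](=O)[O-]` gives 10000 nM, the lowest number of the three and clearly lower than that of compound 1.

Compound 4 `COc1cc(-c2nccn2-c2cccc([N+](=O)[O-])c2)cc(OC)c1OC` carries hydrogen in place of methoxy on an aromatic carbon, ortho to a nitro group (hydrogen in place of methoxy on an aromatic carbon).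

Going by the values given here, the only measured step, an at least 1.5-fold higher number from compound 1 to compound 2 (0.19 log units; that floor lies within the scatter), concerns a different substituent and rests on a limit, so it offers only weak guidance on size. Among the compounds with values here, no measured step covers the loss of this methoxy group. With compound 3 at 10000 nM and the other two compounds higher, any drift is expected toward a higher number, but no step beyond the scatter is expected in this assay. The expected change is a 1.7-fold higher number from compound 3 to compound 4 (0.23 log units; within the scatter).

For compound 4 the estimated value is 17000 nM, with an expected range from 5000 nM to 60000 nM.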

Compound 4, half-maximal inhibitory concentration: 17900 nM
Beside the measured number, compound 4's estimate is 1.1-fold (0.02 log units) below it; the range from low to high includes it.
By their numbers in this assay, from the lowest: compounds 3 and 4 (each within the scatter of the next); then compound 1. At a limit, above all of these: compound 2.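

Working from the lead nitro compound in this assay, this is the first measured change at the aromatic carbon ortho to a nitro group, and hydrogen in place of methoxy gives a 1.8-fold higher number from compound 3 to compound 4 (0.25 log units; within the scatter). The methoxy group at this carbon can therefore be lost without a step beyond the scatter, and compound 3 and compound 4 cannot be ordered on these numbers. This rests on a single pair, and nothing measured on these groups bears on why the step is this size.

The compounds shown leave open whether a different group on this carbon, such as an amine, fluorine or ethoxy, would move the number beyond the scatter. They also leave open whether the nitro group itself can give way to a nitrile or an amine.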